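The source may hold more compounds than are shown below. What is called first, only, known or untested is meant among the compounds shown, and "the series" means these compounds.

The measured compounds and their values:

compound 1 `C[C@@H]1CC[C@@H]2[C@@H](C1)O[C@@H](c1ccc(O)cc1)CC2(C)O` — in an ADME assay on MDCK cells (Canis lupus familiaris) for cytotoxicity, read by MTT assay, with a stated time of 48 h (a lower number here means that less compound is tolerated, a higher number that more compound is tolerated), compound 1 gives 127000 nM
compound 2 `C[C@@H]1CC[C@@H]2[C@@H](C1)O[C@@H](c1ccc(O)cc1)CC2(C)F` — compound 2 gives 95000 nM
compound 3 `COc1cc([C@H]2CC(C)(F)[C@@H]3CC[C@@H](C)C[C@H]3O2)ccc1O` — compound 3 gives 642000 nM

Compound 2 holds the lowest of the three numbers in this assay. Its nearest neighbour is compound 1, and the step of a 1.3-fold lower number from compound 1 to compound 2 (0.13 log units; within the scatter) is within the scatter, so no order between these two is claimed. The step of a 6.8-fold higher number from compound 2 to compound 3 (0.83 log units; beyond the scatter) is beyond the scatter and separates compound 2 from compound 3, which carries the highest number.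

Compound 4 `C[C@@H]1CC[C@@H]2[C@@H](C1)O[C@@H](c1ccc([N+](=O)[O-])cc1)CC2(C)F` is the next compound. It differs from compound 2 in one place: nitro in place of hydroxy on an aromatic carbon. Neither measured step matches this change. The step of a 1.3-fold lower number from compound 1 to compound 2 (0.13 log units; within the scatter) concerns a saturated ring carbon, not the aromatic ring, and the step of a 6.8-fold higher number from compound 2 to compound 3 (0.83 log units; beyond the scatter) adds a group rather than exchanging one. Both steps are small to modest, so a step of no more than modest size is expected for compound 4 in this assay, with the direction left open. The expected step is a 1.2-fold higher number from compound 2 to compound 4 (0.06 log units; within the scatter). Compound 4 is therefore estimated at 110000 nM, with a range from 40000 nM to 300000 nM.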

Compound 4, half-maximal cytotoxic concentration: > 976000 nM
Compound 4 was reported as a limit; the forecaster's own chance of this, stated with the estimate: 10%; middle value at least 8.8-fold (0.94 log units) away from the limit.
By their numbers in this assay, from the lowest: compounds 2 and 1 (each within the scatter of the next); then compound 3. At a limit, above all of these: compound 4.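

In this assay, all three earlier compounds keep hydroxy on the aromatic carbon para to a large group, so they said nothing about this position; exchanging that hydroxy for nitro gives an at least 10-fold higher number from compound 2 to compound 4 (1.01 log units; beyond the scatter). This is the only step shown that is rated large, whereas the exchange on the saturated ring carbon stayed within the scatter and a 6.8-fold higher number from compound 2 to compound 3 (0.83 log units; beyond the scatter) was modest, so this aromatic position shows a stronger response in this assay than either place changed before. The result for compound 4 is a limit and not a number, so the step gives no exact size: the limit of > 976000 nM in this assay, at which 1 of the 4 values shown sits.

The compounds shown leave open whether the step comes from losing the hydroxy or from gaining the nitro, a question that an amine, a carboxylic acid or a methoxy at the same position could help to separate. They also leave open whether the same exchange would carry over to compound 1, with its hydroxy on the saturated ring carbon, or to compound 3, with its methoxy on the aromatic ring.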